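Swapping the anilino ring: from dimethoxy-chloro to dimethyl

A few compounds are considered here, and "the series" means these few. Any claim that something is new, unique, unknown or untested is made for them only; others in the source may bear on it.

Compound 1 `CN(c1cccc2c1CN(c1nc(Nc3cccc(C(F)(F)F)c3)ncc1C(F)(F)F)C2)S(C)(=O)=O` gives only a limit in a functional assay on A549 cells (Homo sapiens) for antiproliferative activity, read by spectrophotometry, with a stated time of 2 days; a lower number here means a stronger inhibitor of growth, a higher number a weaker inhibitor of growth: > 30000 nM.
Compound 2 `COc1cc(Nc2ncc(C(F)(F)F)c(N3Cc4cccc(N(C)S(C)(=O)=O)c4C3)n2)c(OC)cc1Cl` gives 7300 nM in this assay.

Two compounds share a core and differ only in the ring carried on the nitrogen on an aromatic ring. Compound 1 sits at the assay's limit, a ceiling rather than a measured number (the limit of > 30000 nM in this assay, at which 1 of the 2 values shown sits). Going by the values given here, compound 2 holds the only real number among the pair, so it is the reference point here. The step of an at least 4.1-fold lower number from compound 1 to compound 2 (0.61 log units; beyond the scatter) shows that exchanging the anilino ring can move the read-out by at least a modest amount.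

Compound 3 `Cc1ccc(Nc2ncc(C(F)(F)F)c(N3Cc4cccc(N(C)S(C)(=O)=O)c4C3)n2)c(C)c1` has not yet been measured. The change 2,4-dimethylphenyl in place of 4-chloro-2,5-dimethoxyphenyl on a nitrogen on an aromatic ring removes both methoxy groups and the chlorine and brings in two methyl groups instead. Among the compounds with values here, the only step measured bears on this position, but it ran from a limit to a number, so its true size is unknown. Without acceptors on the ring, a weaker result than compound 2 is expected, with a real chance of another limit.

Compound 3 is expected to give 15000 nM in this assay, between 5000 nM and 40000 nM. That expected step a 2.1-fold higher number from compound 2 to compound 3 (0.31 log units; beyond the scatter) lies beyond the scatter but stays uncertain.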

Compound 3, concentration for 50% growth inhibition: 20700 nM
Compound 3: the middle estimate sits 1.4-fold (0.14 log units) below what was measured, within the range that was stated.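

In this assay, going by these compounds alone, the change from compound 2 to compound 3 is the first at this position that can be sized in full, since both ends are real numbers: a 2.8-fold higher number from compound 2 to compound 3 (0.45 log units; beyond the scatter). It shows that the ring on this nitrogen does not need the methoxy groups or the chlorine for a growth-inhibition value to be read, although 4-chloro-2,5-dimethoxyphenyl keeps the lower number of the two. The comparison with 3-(trifluoromethyl)phenyl is less firm, as it gives only an at least 1.4-fold lower number from compound 1 to compound 3 (0.16 log units; that floor lies within the scatter), so compound 1 and compound 3 cannot be put in order and the true size of the gap stays hidden behind a limit: the limit of > 30000 nM in this assay, at which 1 of the 3 values shown sits.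

Because 2,4-dimethylphenyl differs from 4-chloro-2,5-dimethoxyphenyl in several groups at once, the compounds shown cannot tell whether the methoxy groups, the chlorine or the methyl groups account for the step. As far as these compounds go, it also remains open how this position would respond to a ring carrying an amine or a carboxylic acid, or to a ring with the chlorine as its only substituent.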